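Carbamate amine variants on a ceramide-like scaffold

The source may report more compounds than this note shows. Statements on the series, on what has been measured and on what is new or still open speak of the compounds shown alone.

Measured compounds:
compound 1 `CCCCCCCCCCCCC/C=C/[C@@H](O)[C@H](COC(=O)CCCN(C)C)NC(=O)C(C)(C)C` — 31000 nM
compound 2 `CCCCCCCCCCCCC/C=C/[C@@H](O)[C@H](COC(=O)NCCN(C)C)NC(=O)C(C)(C)C` — 4100 nM
compound 3 `CCCCCCCCCCCCC/C=C/[C@@H](O)[C@H](COC(=O)NCC[N+](C)(C)C)NC(=O)C(C)(C)C` — 8700 nM

Three compounds share the same lipid core and differ only in the basic group carried by the ester or carbamate. In an assay on membranes from brain for inhibition of sphingomyelin phosphodiesterase 2 (Rattus norvegicus), using microsomes (a lower number here means a stronger inhibitor, a higher number a weaker inhibitor), compound 1 gives 31000 nM, the highest number of the three. Compound 2 gives 4100 nM in this assay, and compound 3 gives 8700 nM. Compound 3 thus sits second highest, with compound 2 nearest and compound 1 furthest from it.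

Compound 4 `CCCCCCCCCCCCC/C=C/[C@@H](O)[C@H](COC(=O)NCCN(C(C)C)C(C)C)NC(=O)C(C)(C)C` is the next compound. It differs from compound 3 by a group of 7 heavy atoms (6 carbon, 1 nitrogen; no ring) in place of a group of 4 heavy atoms (3 carbon, 1 nitrogen; no ring), on a saturated chain carbon, two bonds along the chain from an amide-type nitrogen. Among the compounds with values here, the step that bears on this change most directly is a 2.1-fold higher number from compound 2 to compound 3 (0.33 log units; beyond the scatter), where the charged group replaced the uncharged dimethylamino; compound 4 reverses that exchange and adds bulk on the nitrogen, for which no measured step exists. The step of a 3.6-fold lower number from compound 1 to compound 3 (0.55 log units; beyond the scatter) shows only that the carbamate arrangement gave lower numbers than the ester.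

The expectation for compound 4 is therefore a modest step back toward the number of compound 2, a 1.9-fold lower number from compound 3 to compound 4 (0.29 log units; within the scatter). Compound 4 is estimated at 4500 nM in this assay, within 1500 nM to 14000 nM.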

Compound 4, half-maximal inhibitory concentration: 18000 nM
Estimate against measurement, compound 4: 4.0-fold (0.60 log units) below; measured number above the stated range.
By their numbers in this assay, from the lowest: compound 2; then compound 3; then compounds 4 and 1 (each within the scatter of the next).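

The exchange of dimethylamino for diisopropylamino on the saturated chain carbon, two bonds along the chain from an amide-type nitrogen, gives a 4.4-fold higher number from compound 2 to compound 4 (0.64 log units; beyond the scatter) in this assay, the first measured sign that the substituents on this amine nitrogen matter while the carbamate stays in place. With a 2.1-fold higher number from compound 3 to compound 4 (0.32 log units; beyond the scatter) as well, the three groups at this position rank dimethylamino, then the charged group of compound 3, then diisopropylamino, and a 1.7-fold lower number from compound 1 to compound 4 (0.24 log units; within the scatter) shows that the carbamate with diisopropylamino is not separated from the compound 1 ester, so the carbamate alone does not secure the lower numbers seen for compound 2 and compound 3. No measurement shown here accounts for these differences.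

On these data alone, whether diethylamino or a pyrrolidine ring on the same chain would fall between dimethylamino and diisopropylamino remains open. The compounds shown also leave open how a longer chain between the carbamate nitrogen and the dimethylamino group would read in this assay, and so whether the chain and the amine substituents act independently.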